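A Shorter Arm on the Shared Core: Compound 3

This account rests on a few compounds, and the source may have more. Where it says the series, first, only, none or still open, it means among the compounds named here.

Compound 2 `CCCCC(=O)OCc1ccc2oc(=O)c(C(=O)Oc3cccc(Br)c3)cc2c1` carries an ester arm, and in a functional assay on HT-1080 cells (Homo sapiens), read by transwell migration, with a stated time of 24 h, tested at 10 uM (a lower number here means a stronger effect, a higher number a weaker effect of the compound at the concentration tested), compound 2 gives 32.3%, the lowest of the two measured values. Compound 1 `CC(=O)OCc1ccc2oc(=O)c(C(=O)Sc3ccccc3)cc2c1` carries a different arm, and in this assay compound 1 gives 73.8%, a weaker effect by a gap beyond the scatter. Compound 3 `NCc1ccc2oc(=O)c(C(=O)Oc3cccc(Br)c3)cc2c1` has not been measured. Its change from compound 2: amino in place of (butylcarbonyl)oxy on a saturated chain carbon bound to an aromatic carbon. Among the measured compounds shown here, no step between measured compounds covers such a change, so a loss of effect beyond the scatter is only an expectation, an expected step of a number 19.7 percentage points higher from compound 2 to compound 3 (beyond the scatter). Compound 3 is therefore expected to give 52%, within 28% to 80%.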

Compound 3, a percentage reported as activity, at one concentration (the size of the read-out at that concentration, not a potency): 63.6%
Compound 3: the middle estimate sits 11.6 percentage points below what was measured; the measured number falls inside the stated range.
By their numbers in this assay, from the lowest: compound 2; then compound 3; then compound 1.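

On a saturated chain carbon bound to an aromatic carbon, putting amino in place of (butylcarbonyl)oxy weakens the effect in this assay, with a number 31.3 percentage points higher from compound 2 to compound 3 (beyond the scatter). Among the compounds shown here, this is the first comparison in which only one place changes, and it shows that the group held there matters in this assay. Nothing shown explains the loss. On these data alone, whether it comes from losing the ester arm or from gaining the amino group stays open. A carboxylic acid or an amide at this place could help separate the two.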